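From pyridin-3-yl to 3-methylpyridin-2-yl: a step past a limit

The source may hold more compounds than are shown below. What is called first, only, known or untested is meant among the compounds shown, and "the series" means these compounds.

Measured so far in an ADME assay on HepG2 cells (Homo sapiens) for cytotoxicity, with a stated time of 72 h; a lower number here means that less compound is needed, a higher number that more compound is needed for the effect:
Compound 1 `Cc1cc(NC(=O)Nc2cccc(F)c2)c2ccccc2n1`: > 25000 nM (a limit)
Compound 2 `Cc1cc(NC(=O)Nc2cccnc2)c2ccccc2n1`: > 25000 nM (a limit)

Compound 2 stands at a limit of the assay, not at a number, and the whole record so far is the limit of > 25000 nM in this assay, at which 2 of the 2 values shown sit. Compound 3 `Cc1cc(NC(=O)Nc2ncccc2C)c2ccccc2n1` keeps the shared core and carries 3-methylpyridin-2-yl in place of pyridin-3-yl on an amide-type nitrogen. Among the measured compounds shown here, the only measured step, a step that the two limits leave unreadable from compound 1 to compound 2, also exchanged the group at this place, but it gives no size to carry over. No step beyond the scatter is therefore expected in this assay, and no direction can be predicted. The assay will most likely report only a limit again. Should a number appear, compound 3 is estimated at 30000 nM, with a range from 12000 nM to 60000 nM. The expected step is a step that the limit leaves unreadable from compound 2 to compound 3.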

Compound 3, half-maximal effective concentration: > 25000 nM
Compound 3: only a limit was reported; the forecaster's own chance of this, stated with the estimate: 85%; the middle value is on the limit's open side.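

Compound 1, compound 2 and compound 3 give only limits in this assay, so no step among them can be read: the limit of > 25000 nM in this assay, at which 3 of the 3 values shown sit.

The compounds shown leave open whether exchanging the group on the amide-type nitrogen changes the concentration needed for the effect in this assay.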